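Fluoro in Place of Ethoxy: Expected Cytotoxicity of Compound 4

The source may report more compounds than this note shows. Statements on the series, on what has been measured and on what is new or still open speak of the compounds shown alone.

Three compounds with a shared core have been examined in a functional assay on MT4 cells (Homo sapiens) for cytotoxicity, read by MTT assay; on this read-out lower numbers stand for higher toxicity in this test and higher numbers for lower toxicity in this test. Compound 1 `CCOc1ccc(CSc2nc(O)c(C)c(Cc3c(Cl)cccc3Cl)n2)cc1` returns only a limit there, > 58000 nM. Compound 2 `Cc1c(O)nc(SCc2ccc(C#N)cc2)nc1Cc1c(F)cccc1F` likewise gives a limit, > 65000 nM. Compound 3 `COc1ccc(CSc2nc(O)c(C)c(Cc3c(Cl)cccc3Cl)n2)cc1OC` also reaches no more than a limit, > 55000 nM. Compound 1 therefore stands on the same footing as the other two: each result is a limit of the test and not a number, as the limit of > 55000 nM in this assay, at which 1 of the 3 values shown sits, the limit of > 58000 nM in this assay, at which 1 of the 3 values shown sits, and the limit of > 65000 nM in this assay, at which 1 of the 3 values shown sits, show, and no ordering among the three can be drawn from them.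

Compound 4 `Cc1c(O)nc(SCc2ccc(F)cc2)nc1Cc1c(Cl)cccc1Cl` has not yet been measured in this assay . It differs from compound 1 by fluoro in place of ethoxy on an aromatic carbon. Within the data shown here, no step between two measured compounds is available to size this change. Because all three measured results are limits, the step that the limit leaves unreadable from compound 1 to compound 4 is expected to be none beyond the scatter. Compound 4 is estimated at 60000 nM, with a range from 25000 nM to 120000 nM, and is expected most likely to be reported again as a limit.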

Compound 4, half-maximal cytotoxic concentration: > 61000 nM
Compound 4: no number, only a limit (the forecaster's own chance of this, stated with the estimate: 85%); at least 1.0-fold (0.00 log units) between middle value and limit.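

Compound 1 and compound 4 both return only a limit, and the step from compound 1 to compound 4 cannot be read. The compounds shown leave open at what concentration any of them becomes toxic in this assay, and whether fluoro in place of ethoxy changes that concentration at all.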